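Shifting the methoxy group on the pendant phenyl ring

This account rests on a few compounds, and the source may have more. Where it says the series, first, only, none or still open, it means among the compounds named here.

Compound 1 `N#CC1=C(N)N(c2ccc(S(N)(=O)=O)cc2)C2=C(CCCC2)C1c1ccccc1` was tested in a functional assay on Ehrlich cells (Mus musculus) for cytotoxicity, read by trypan blue exclusion, with a stated time of 2 h, tested at 50 ug/mL (on this read-out lower numbers stand for a weaker effect and higher numbers for a stronger effect at the one concentration tested), where compound 1 gives 20%. Compound 2 `Cc1ccc(C2C(C#N)=C(N)N(c3ccc(S(N)(=O)=O)cc3)C3=C2CCCC3)cc1` gives 80% in this assay, and compound 3 `COc1ccccc1C1C(C#N)=C(N)N(c2ccc(S(N)(=O)=O)cc2)C2=C1CCCC2` gives 50%. On these three numbers compound 3 stands second highest, beyond the scatter from compound 1 on one side and beyond the scatter from compound 2 on the other. The measured steps are a number 60 percentage points higher from compound 1 to compound 2 (beyond the scatter) and a number 30 percentage points higher from compound 1 to compound 3 (beyond the scatter), each adding a group to the aromatic ring, together with a number 30 percentage points lower from compound 2 to compound 3 (beyond the scatter).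

Compound 4 `COc1ccc(C2C(C#N)=C(N)N(c3ccc(S(N)(=O)=O)cc3)C3=C2CCCC3)cc1` differs from compound 3 as follows: 4-methoxyphenyl in place of 2-methoxyphenyl on a saturated ring carbon. Two of the measured steps bear on this change. The step of a number 60 percentage points higher from compound 1 to compound 2 (beyond the scatter) shows that the 4-methylphenyl compound sits highest, and the step of a number 30 percentage points lower from compound 2 to compound 3 (beyond the scatter) shows that the 2-methoxyphenyl compound sits lower than it. Going by the values given here, no measured step moves a methoxy group from one place to another on this ring, so the expectation rests on compound 2 standing highest with its 4-methylphenyl group. Compound 4 is therefore expected to rise by a modest amount, a number 15 percentage points higher from compound 3 to compound 4 (beyond the scatter), in this assay. The estimate for compound 4 is 65%, expected to fall between 40% and 90%.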

Compound 4, a percentage reported as activity, at one concentration (the size of the read-out at that concentration, not a potency): 100%
Compound 4: the middle estimate sits 35 percentage points below what was measured; measured number outside the range, above it.
By their numbers in this assay, from the lowest: compound 1; then compound 3; then compound 2; then compound 4.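

Moving the methoxy group while keeping the same atoms produces a number 50 percentage points higher from compound 3 to compound 4 (beyond the scatter) in this assay, so on this phenyl ring, carried on the saturated ring carbon, the placement of the methoxy group alone changes the read-out by a large amount, something the earlier compounds, with only the 2-methoxyphenyl group, could not show. With the substituent in the same place, methoxy also stands apart from methyl, with a number 20 percentage points higher from compound 2 to compound 4 (beyond the scatter), and the 4-methoxyphenyl group gives a number 80 percentage points higher from compound 1 to compound 4 (beyond the scatter), the largest rise over the plain phenyl compound among the compounds shown. Nothing at hand explains why the placement of the methoxy group matters so much here.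

The compounds shown leave open whether a methyl group would respond to the same shift around the ring, and whether a 4-ethoxyphenyl or a 4-hydroxyphenyl group would keep the read-out as high. They also leave open how compound 4 would behave at other concentrations, as its 100% gives the size of the effect at one concentration only.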